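Swapping fluoro for carbamoyl on an inactive parent

The source may hold more compounds than are shown below. What is called first, only, known or untested is meant among the compounds shown, and "the series" means these compounds.

Compound 1 `CC[C@@H]1C(=O)N(C)c2cnc(-n3ccc4cc(F)ccc43)nc2N1C1CCCC1` carries a fluoro group on its fused bicyclic arm, and in a functional assay on HeLa cells (Homo sapiens) for antiproliferative activity, read by CCK-8 assay, with a stated time of 72 h (a higher number here means a weaker inhibitor of growth, a lower number a stronger inhibitor of growth), compound 1 gave "not active" (no number reported), so no single number places it among the others. Two relatives with a different arm were measured: compound 2 `CC[C@@H]1C(=O)N(C)c2cnc(Nc3ccc(S(N)(=O)=O)cc3)nc2N1C1CCCC1` gives 317 nM in this assay, and compound 3 `CCC1C(=O)N(C)c2cnc(Nc3ccc(S(=O)(=O)NCC(C)C)cc3)nc2N1c1ccn(C)n1` gives 5310 nM in this assay. Compound 4 `CC[C@@H]1C(=O)N(C)c2cnc(-n3ccc4cc(C(N)=O)ccc43)nc2N1C1CCCC1` keeps the core of compound 1 and differs only in that (carbamoyl in place of fluoro on an aromatic carbon). Within the data shown here, no measured step exists for such a pair, and any gain from this change in this assay is expected to be modest at most, since compound 1 itself gave "not active" (no number reported). Compound 4 is therefore estimated at 6000 nM in this assay, within 1000 nM to 40000 nM, with a real chance of again reading only as inactive.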

Compound 4, concentration for 50% growth inhibition: 674 nM
Compound 4: the middle estimate sits 8.9-fold (0.95 log units) above what was measured; measured number outside the range, below it.
By their numbers in this assay, from the lowest: compound 2; then compound 4; then compound 3.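

In this assay, among these compounds, compound 1 gives "not active" (no number reported) and so no step to compound 4 can be read. The compounds shown leave open how much carbamoyl in place of fluoro changes growth inhibition. No measurement shown offers a reason for the result of compound 4.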